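The compounds below may be only part of what the source reports. "The series", "measured", "known", "first", "only" and "open" are said of these compounds alone.

Measured compounds in an ADME assay on Vero cells (Chlorocebus sabaeus) for cytotoxicity, read by MTT assay, with a stated time of 48 h; a lower number here means that less compound is tolerated, a higher number that more compound is tolerated:

- compound 1 `O=C(NCCCc1ccc(Cl)cc1)c1ccc([N+](=O)[O-])o1` gives 19000 nM
- compound 2 `CC(NC(=O)c1ccc([N+](=O)[O-])o1)c1ccccc1` gives 24000 nM
- compound 3 `CC(C)(NC(=O)c1ccc([N+](=O)[O-])o1)c1ccccc1` gives > 180000 nM

Compound 3 is reported only as a limit, (the limit of > 180000 nM in this assay, at which 1 of the 3 values shown sits); no number is known for it, and its standing against compound 1 and compound 2 cannot be placed more closely than that. Among the compounds with values here, the single step among the measured compounds, an at least 7.5-fold higher number from compound 2 to compound 3 (0.87 log units; beyond the scatter), concerns methyl in place of hydrogen on the saturated chain carbon and does not touch the ring that is changed next.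

Compound 4 `CC(C)(NC(=O)c1ccc([N+](=O)[O-])o1)c1ccc(-c2ccc(Cl)cc2)cc1` differs from compound 3 by 4-chlorophenyl in place of hydrogen on an aromatic carbon. Within the data shown here, no measured step bears on this change: nothing among the three measured compounds adds a group to that aromatic carbon, so the size and direction of the step are unsupported by the series. Since compound 3 already sits at the limit, only a lower number for compound 4 could be distinguished from it. Compound 4 is estimated at 90000 nM, with a range of 25000 nM to 180000 nM. The expected step is therefore an at least 2.0-fold lower number from compound 3 to compound 4 (0.30 log units; that floor lies within the scatter), with a real chance that this assay again reports only a limit.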

Compound 4, half-maximal cytotoxic concentration: > 140000 nM
Compound 4: a limit, no number; the forecaster's own chance of this, stated with the estimate: 40%; middle value at least 1.5-fold (0.19 log units) away from the limit.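

Compound 3 and compound 4 are both reported only as limits in this assay, and no step can be read between them. The compounds shown leave open whether 4-chlorophenyl in place of hydrogen on that aromatic carbon shifts the number at all, and in which direction.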